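Working notes on tolerated concentration, compound 3 to compound 4

This account rests on a few compounds, and the source may have more. Where it says the series, first, only, none or still open, it means among the compounds named here.

Measured in an ADME assay on HEL cells (Homo sapiens) for cytotoxicity; a lower number here means that less compound is tolerated, a higher number that more compound is tolerated:
- compound 1 `O=C(COc1cccc2ccccc12)N/N=C/c1ccc(O)cc1` gives 20 ug/mL.
- compound 2 `CSc1ccc(/C=N/NC(=O)COc2cccc3ccccc23)cc1` gives >= 100 ug/mL; this is a limit of the assay, not a number.
- compound 3 `O=C(COc1cccc2ccccc12)N/N=C/c1ccccc1Cl` gives 100 ug/mL.

Compound 3 holds the highest of the two numbers; its nearest neighbour is compound 1, with a 5.0-fold higher number from compound 1 to compound 3 (0.70 log units; beyond the scatter). Compound 2 sits at the limit (the limit of >= 100 ug/mL in this assay, at which 1 of the 3 values shown sits), so its distance from compound 3 cannot be read: a number no higher from compound 2 to compound 3 (the limit leaves the size open).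

Compound 4 `COc1ccc(/C=N/NC(=O)COc2cccc3ccccc23)cc1` is not yet measured. Its change from compound 3 is 4-methoxyphenyl in place of 2-chlorophenyl on a carbon with a double bond to nitrogen.

For the measured compounds named here, two measured steps bear on this. Replacing hydroxy by methylsulfanyl on the aromatic carbon gave an at least 5.0-fold higher number from compound 1 to compound 2 (0.69 log units; beyond the scatter), and moving from 4-hydroxyphenyl to 2-chlorophenyl gave a 5.0-fold higher number from compound 1 to compound 3 (0.70 log units; beyond the scatter). Both point the same way: the hydroxy-bearing compound 1 is the one tolerated least, while the other two variants reach the region of the limit. Compound 4 carries a 4-methoxyphenyl, again without a hydrogen-bond donor, so the expectation is that compound 4 stays near the limit, with no change at the digits printed from compound 3 to compound 4 (within the scatter), and an estimated value of 100 ug/mL, within 50 ug/mL to 200 ug/mL, quite possibly reported only as a limit.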

Compound 4, minimum cytotoxic concentration: 20 ug/mL
For compound 4 the middle estimate is 5.0-fold (0.70 log units) above the measured one; measured number outside the range, below it.
By their numbers in this assay, from the lowest: compounds 1 and 4 (each within the scatter of the next); then compound 3.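

In this assay, methyl in place of hydrogen on an oxygen on an aromatic ring gives no change at the digits printed from compound 1 to compound 4 (within the scatter), so the low number of compound 1 does not depend on the hydroxy hydrogen. On the carbon with a double bond to nitrogen, 4-methoxyphenyl in place of 2-chlorophenyl gives a 5.0-fold lower number from compound 3 to compound 4 (0.70 log units; beyond the scatter), and methoxy in place of methylsulfanyl on an aromatic carbon gives an at least 5.0-fold lower number from compound 2 to compound 4 (0.69 log units; beyond the scatter); among the four compounds, the two with an oxygen on the aromatic ring thus share the low end, and no compound shown goes against this. The value of compound 2 is a limit, not a number: the limit of >= 100 ug/mL in this assay, at which 1 of the 4 values shown sits.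

As far as these compounds go, whether 2-chlorophenyl owes its higher number to the chlorine or to where the chlorine sits remains open, with 4-chlorophenyl a natural comparison. From the compounds shown here alone, how an amine or a longer alkoxy chain would read in place of methoxy is also open.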